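The source may report more compounds than this note shows. Statements on the series, on what has been measured and on what is new or still open speak of the compounds shown alone.

Measured so far:
Compound 1 `CCCCCCC[C@H]1C[C@H](Cl)CCN1S(=O)(=O)c1ccc(C)cc1`. In a functional assay on A2780 cells (Homo sapiens) for antiproliferative activity, read by sulforhodamine B assay, with a stated time of 48 h (a higher number here means a weaker inhibitor of growth, a lower number a stronger inhibitor of growth), compound 1 gives > 100000 nM, a limit of the assay.
Compound 2 `Cc1ccc(S(=O)(=O)N2CCC(Br)CC2)cc1`. In this assay compound 2 gives > 100000 nM, likewise only a limit.

Among the compounds with values here, compound 2 thus stands at the limit of > 100000 nM in this assay, at which 2 of the 2 values shown sit, and no step between measured compounds exists to calibrate the series. Compound 3 `Cc1ccc(S(=O)(=O)N2CC[C@@H](Br)C[C@@H]2C2CCCCC2)cc1` differs from compound 2 by cyclohexyl in place of hydrogen on a saturated ring carbon. Compound 1, also a substituted analogue of the shared core, sits at the limit as well. The expected step from compound 2 to compound 3 is a number no higher from compound 2 to compound 3 (the limit leaves the size open), most likely none beyond the scatter. Compound 3 is estimated at 100000 nM, between 30000 nM and 300000 nM.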

Compound 3, concentration for 50% growth inhibition: > 100000 nM
Compound 3 ended at the assay's limit; the forecaster's own chance of this, stated with the estimate: 70%; the middle value sits exactly at the limit.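

Within the data shown here, compound 2 and compound 3 both stand at a limit in this assay, which leaves no step readable for cyclohexyl in place of hydrogen on a saturated ring carbon. The compounds shown leave open which change to the shared core, if any, gives a value inside the range of this assay.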